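Methylsulfanyl for methoxy on the fused core of compound 3

This account rests on a few compounds, and the source may have more. Where it says the series, first, only, none or still open, it means among the compounds named here.

Compound 3 `COc1cc(OC)n2s/c(=N\C(=O)c3c(-c4ccc(Cl)cc4Cl)noc3C)nc2n1` stands highest of the three compounds measured in a functional assay on the whole organism for inhibition, with Digitaria ciliaris as the target, with a stated time of 72 h, tested at 10 mg/L; a higher number here means more inhibition of growth at the concentration tested, a lower number less inhibition of growth. In this assay compound 3 gives 53.8%. Compound 2 `Cc1onc(-c2ccc(Cl)cc2Cl)c1C(=O)/N=c1/nc2nc(Cl)cc(C)n2s1` gives 32.8% in this assay, a number lower than that of compound 3 by more than the scatter. Compound 1 `COc1cc(Cl)nc(NC(=S)NC(=O)c2c(-c3ccc(Cl)cc3Cl)noc2C)n1` gives 14.6% in this assay, the furthest below compound 3, again beyond the scatter.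

Compound 4 `COc1cc(SC)nc2n/c(=N/C(=O)c3c(-c4ccc(Cl)cc4Cl)noc3C)sn12` differs from compound 3 by methylsulfanyl in place of methoxy on an aromatic carbon. Going by the values given here, no pair of measured compounds shares this exchange, so nothing measured shows how large a step it brings. The expectation is therefore anchored on compound 3, which carries the methoxy group at that place and gives 53.8% in this assay. The step expected in this assay amounts to a number 5.8 percentage points lower from compound 3 to compound 4 (within the scatter), a change that stays within the usual scatter, with no settled direction. Compound 4 is estimated at 48% in this assay, with a range from 25% to 70%.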

Compound 4, percent growth inhibition at one concentration: 19.8%
For compound 4 the middle estimate is 28.2 percentage points above the measured one; measured number below the stated range.
By their numbers in this assay, from the lowest: compounds 1 and 4 (each within the scatter of the next); then compound 2; then compound 3.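

In this assay, going by these compounds alone, this position proves sensitive: methylsulfanyl in place of methoxy on an aromatic carbon brings a number 34 percentage points lower from compound 3 to compound 4 (beyond the scatter) and is the first step that isolates one place. The exchange keeps the count of heavy atoms and of hydrogen-bond acceptors and replaces only oxygen with sulfur, yet the step is large, so the methoxy group at this place matters for the growth inhibition of compound 3 at the concentration tested. Nothing at hand accounts for the loss.

As far as these compounds go, only methoxy and methylsulfanyl are seen at this place, so it remains open whether the loss is specific to methylsulfanyl or follows from any departure from methoxy. An amine or an ethoxy chain on the same carbon would help separate these two readings.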